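Amide aryl variation on the shared core: towards compound 4

The source may report more compounds than this note shows. Statements on the series, on what has been measured and on what is new or still open speak of the compounds shown alone.

Working notes on a small amide series. Compound 1 `O=C(Nc1cccc(-c2oc3cc(-c4ccc(F)cc4)ccc3c(=O)c2O)c1)c1ccc(F)cc1` gives 9280 nM in a functional assay on HepG2 cells (Homo sapiens) for antiproliferative activity, read by CCK-8 assay, with a stated time of 72 h; a lower number here means a stronger inhibitor, a higher number a weaker inhibitor. Compound 2 `COc1cccc(C(=O)Nc2cccc(-c3oc4cc(-c5ccc(F)cc5)ccc4c(=O)c3O)c2)c1` gives 9950 nM in this assay, and the move a 1.1-fold higher number from compound 1 to compound 2 (0.03 log units; within the scatter) changes nothing of note. Compound 3 `O=C(Nc1cccc(-c2oc3cc(-c4ccc(F)cc4)ccc3c(=O)c2O)c1)c1ccc(Br)cc1F` reaches only the limit of this assay, at > 100000 nM, so no number is known for it; the limit of > 100000 nM in this assay, at which 1 of the 3 values shown sits, records this. The measured steps of an at least 10-fold higher number from compound 1 to compound 3 (1.03 log units; beyond the scatter) and an at least 10-fold higher number from compound 2 to compound 3 (1.00 log units; beyond the scatter) therefore end at that limit, and compound 3 stands as the weakest of the three by a margin beyond the scatter.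

Compound 4 `CCCc1ccc(C(=O)Nc2cccc(-c3oc4cc(-c5ccc(F)cc5)ccc4c(=O)c3O)c2)cc1` is not yet measured. It differs from compound 3 by 4-propylphenyl in place of 4-bromo-2-fluorophenyl on a carbonyl carbon. The two steps that bear on it run the other way round: where 4-fluorophenyl and 3-methoxyphenyl gave numbers near each other, 4-bromo-2-fluorophenyl lost them. Removing that group is expected to bring the number back towards the values of compound 1 and compound 2, so the step of an at least 6.6-fold lower number from compound 3 to compound 4 (0.82 log units; beyond the scatter) is expected to be a clear fall in this assay. For compound 4 the estimate is 15000 nM, between 5000 nM and 60000 nM.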

Compound 4, half-maximal inhibitory concentration: 51500 nM
The estimate for compound 4 lay 3.4-fold (0.54 log units) below the measured number, within the range that was stated.
By their numbers in this assay, from the lowest: compounds 1 and 2 (each within the scatter of the next); then compound 4. At a limit, above all of these: compound 3.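

The steps of a 5.2-fold higher number from compound 2 to compound 4 (0.71 log units; beyond the scatter) and a 5.5-fold higher number from compound 1 to compound 4 (0.74 log units; beyond the scatter) show that the close agreement between 4-fluorophenyl and 3-methoxyphenyl on this carbonyl carbon does not extend to 4-propylphenyl, so this place in this assay tolerates some aryl changes but not all. The step of an at least 1.9-fold lower number from compound 3 to compound 4 (0.28 log units; that floor lies within the scatter) has a floor that lies within the scatter, so 4-propylphenyl is not shown to differ from 4-bromo-2-fluorophenyl. Compound 3 remains a limit and not a number: the limit of > 100000 nM in this assay, at which 1 of the 4 values shown sits.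

The compounds shown leave open how far the true gap between these two groups extends. They also leave open how an aryl group carrying a methyl, a longer chain, an amine or a carboxylic acid in place of the propyl would read on the shared core.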